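The compounds below may be only part of what the source reports. "The series", "measured", "known", "first", "only" and "open" are said of these compounds alone.

Measured in a functional assay on PC-3 cells (Homo sapiens) for antiproliferative activity, read by MTT assay, with a stated time of 24 h; a lower number here means a stronger inhibitor, a higher number a weaker inhibitor:
- compound 1 `CCn1c(C(=O)N[C@@H](CC(=O)OC)C(=O)OC)ccc1C(CC)(CC)c1ccc(OCS(=O)(=O)c2ccccc2)c(C)c1`: 6490 nM
- compound 2 `CCn1c(C(=O)NC(C)(C)CO)ccc1C(CC)(CC)c1ccc(OCS(=O)(=O)c2ccccc2)c(C)c1`: 9850 nM
- compound 3 `CCn1c(C(=O)N[C@H](CO)CCO)ccc1C(CC)(CC)c1ccc(OCS(=O)(=O)c2ccccc2)c(C)c1`: 12100 nM

These three compounds share a core and differ only in the group on the amide-type nitrogen. Compound 3, at 12100 nM, cannot be separated from the other two. The comparisons are a 1.2-fold higher number from compound 2 to compound 3 (0.09 log units; within the scatter) and a 1.9-fold higher number from compound 1 to compound 3 (0.27 log units; within the scatter).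

Compound 4 `CCn1c(C(=O)N[C@@H](CO)CCO)ccc1C(CC)(CC)c1ccc(OCS(=O)(=O)c2ccccc2)c(C)c1` is the next compound to be tested, and its relation to compound 3 is simple: the two compounds have the same atoms and bonds and differ only in configuration as drawn: 1 of 1 stereo elements differ; a stereocentre at a saturated chain carbon is drawn S in compound 3 and R in compound 4. Nothing leaves and nothing enters.

Within the data shown here, no measured pair in this set isolates a change of configuration, so the data give no direct reading of this step. The nearest evidence comes from changes to the same group. Replacing 1,2-bis(methoxycarbonyl)ethyl with 1-(hydroxymethyl)-1-methylethyl gave a 1.5-fold higher number from compound 1 to compound 2 (0.18 log units; within the scatter). Replacing 1-(hydroxymethyl)-1-methylethyl with 3-hydroxy-1-(hydroxymethyl)propyl gave a 1.2-fold higher number from compound 2 to compound 3 (0.09 log units; within the scatter). Neither of these larger structural changes moved the number beyond the scatter in this assay, so no shift beyond the scatter, in either direction, is expected here, although a stereocentre can still matter in ways these three compounds do not show.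

The estimated step is a 1.1-fold lower number from compound 3 to compound 4 (0.04 log units; within the scatter).

For compound 4 the expected value is 11000 nM, with an estimated range from 5500 nM to 22000 nM.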

Compound 4, half-maximal inhibitory concentration: 14100 nM
Beside the measured number, compound 4's estimate is 1.3-fold (0.11 log units) below it; the range from low to high includes it.
By their numbers in this assay, from the lowest: compounds 1, 2, 3 and 4 (each within the scatter of the next, the first and the last beyond it).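

At the stereocentre of the 3-hydroxy-1-(hydroxymethyl)propyl group, this assay now gives a direct reading of configuration, with a 1.2-fold higher number from compound 3 to compound 4 (0.07 log units; within the scatter), and this pair isolates that single change: the fact that compounds 3 and 4 differ only in the configuration as drawn. Compound 4 also stays close to the tertiary alcohol of compound 2, with a 1.4-fold higher number from compound 2 to compound 4 (0.16 log units; within the scatter), so neither a change of configuration nor a change to this other hydroxylated group separates these compounds in this assay. Among these compounds, the new feature is a 2.2-fold higher number from compound 1 to compound 4 (0.34 log units; beyond the scatter), the first step in the set to pass the scatter, though only modestly, and it applies to the R form alone, since the S form in compound 3 remains within the scatter of compound 1.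

The compounds shown leave open whether an amine or a carboxylic acid in place of a hydroxymethyl arm would move the number further than these modest steps. They also leave open whether configuration matters at the stereocentre of the 1,2-bis(methoxycarbonyl)ethyl group, where only one drawn form appears, in compound 1.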